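One Added Fluoro on the Core of Compound 1

The compounds below may be only part of what the source reports. "The series", "measured", "known", "first", "only" and "open" are said of these compounds alone.

Compound 1 `Fc1cccc(-c2nc(Nc3ccccc3)c3ccccc3n2)c1` was tested in a functional assay on COLO 205 cells (Homo sapiens) for cytotoxicity, read by MTT assay, with a stated time of 48 h; a higher number here means a weaker inhibitor, a lower number a stronger inhibitor. There, compound 1 gives > 50000 nM, which is a limit and not a number. Compound 2 `Fc1ccc2nc(-c3ccccc3)nc(Nc3ccccc3)c2c1` gives > 50000 nM, also a limit. Compound 1 thus stands at the limit of > 50000 nM in this assay, at which 2 of the 2 values shown sit. Compound 3 `Fc1cccc(-c2nc(Nc3ccccc3)c3cc(F)ccc3n2)c1` differs from compound 1 in one place, with fluoro in place of hydrogen on an aromatic carbon. Going by the values given here, no measured step shows what such a change does, so no step beyond the scatter is expected in this assay. The expected size of the step is a number no higher from compound 1 to compound 3 (the limit leaves the size open). Compound 3 is estimated at 50000 nM, within an expected range from 20000 nM to 100000 nM.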

Compound 3, half-maximal inhibitory concentration: 49700 nM
The estimate for compound 3 lay 1.0-fold (0.00 log units) above the measured number; the measured number falls inside the stated range.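

In this assay, going by these compounds alone, compound 3 gives 49700 nM, the first value in this set that is a number and not a limit, and the data show a number no higher from compound 1 to compound 3 (the limit leaves the size open) and a number no higher from compound 2 to compound 3 (the limit leaves the size open) with the size of neither step readable, so whether this fluoro on the fused system changes the result remains unknown. The set as a whole stays close to a single ceiling: the limit of > 50000 nM in this assay, at which 2 of the 3 values shown sit.

The compounds shown leave open whether an amine or a methoxy group on this aromatic carbon would give a clearly lower number. They also leave open what a carboxylic acid on either phenyl ring would do.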